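Dimethylamino to pyrrolidin-1-yl on the saturated chain

The source may hold more compounds than are shown below. What is called first, only, known or untested is meant among the compounds shown, and "the series" means these compounds.

Three measured compounds share one core. In a functional assay on A-431 cells (Homo sapiens) for antiproliferative activity, read by sulforhodamine B assay, with a stated time of 72 h (a lower number here means a stronger inhibitor, a higher number a weaker inhibitor), compound 1 `COCCNC(=O)Nc1cc2c(Nc3ccc(F)c(Cl)c3)ncnc2cc1O[C@H]1CCOC1` gives 387 nM, compound 2 `CS(=O)(=O)CCNC(=O)Nc1cc2c(Nc3ccc(F)c(Cl)c3)ncnc2cc1O[C@H]1CCOC1` gives 1570 nM, and compound 3 `CN(C)CCNC(=O)Nc1cc2c(Nc3ccc(F)c(Cl)c3)ncnc2cc1O[C@H]1CCOC1` gives 806 nM. Compound 3 thus stands second highest of the three, with a 2.1-fold higher number from compound 1 to compound 3 (0.32 log units; beyond the scatter) and a 1.9-fold lower number from compound 2 to compound 3 (0.29 log units; within the scatter). Compound 4 `O=C(NCCN1CCCC1)Nc1cc2c(Nc3ccc(F)c(Cl)c3)ncnc2cc1O[C@H]1CCOC1` differs from compound 3 by pyrrolidin-1-yl in place of dimethylamino on a saturated chain carbon, two bonds along the chain from an amide-type nitrogen. Going by the values given here, no measured step replaces dimethylamino with another group; the steps that exist, a 4.1-fold higher number from compound 1 to compound 2 (0.61 log units; beyond the scatter) and a 2.1-fold higher number from compound 1 to compound 3 (0.32 log units; beyond the scatter), concern methoxy and bear only loosely on this change. One therefore expects no step beyond the scatter, a 1.0-fold lower number from compound 3 to compound 4 (0.00 log units; within the scatter). Compound 4 is estimated at 800 nM in this assay, in a range from 400 nM to 1600 nM.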

Compound 4, half-maximal inhibitory concentration: 247 nM
Compound 4: the middle estimate sits 3.2-fold (0.51 log units) above what was measured; the measured number lies below the stated range.
By their numbers in this assay, from the lowest: compounds 4 and 1 (each within the scatter of the next); then compounds 3 and 2 (each within the scatter of the next).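

Going by these compounds alone, at this place, on a saturated chain carbon, in this assay, closing dimethylamino into pyrrolidin-1-yl changes the result (a 3.3-fold lower number from compound 3 to compound 4 (0.51 log units; beyond the scatter)), which no earlier step could show. The same group gives a larger step from methylsulfonyl (a 6.4-fold lower number from compound 2 to compound 4 (0.80 log units; beyond the scatter)), whereas the step from methoxy (a 1.6-fold lower number from compound 1 to compound 4 (0.20 log units; within the scatter)) does not separate the two compounds. Nothing available accounts for the difference between dimethylamino and pyrrolidin-1-yl. Open, as far as these compounds go, is whether a piperidin-1-yl or morpholin-4-yl ring would behave like pyrrolidin-1-yl here, and whether a longer chain would preserve the step.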